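A Bromine Atom Added to an Analogue at the Limit

The source may hold more compounds than are shown below. What is called first, only, known or untested is meant among the compounds shown, and "the series" means these compounds.

In a functional assay on K562 cells (Homo sapiens) for antiproliferative activity, read by CellTiter-Glo, with a stated time of 72 h (a lower number here means a stronger inhibitor, a higher number a weaker inhibitor), compound 2 `CO[C@@H]1[C@H](N(C)c2ncc(-c3c[nH]c4ccccc34)s2)C[C@H]2O[C@]1(C)n1c3ccccc3c3c4c(c5c6cc(Cl)ccc6n2c5c31)C(=O)NC4` reaches only the limit of > 10000 nM, so no number is known for it. Its companion compound 1 `COc1ccc2[nH]cc(-c3cnc(N(C)[C@@H]4C[C@H]5O[C@@](C)([C@@H]4OC)n4c6ccccc6c6c7c(c8c9ccccc9n5c8c64)C(=O)NC7)s3)c2c1` likewise gives only a limit, > 10000 nM, in this assay. Both known values therefore sit at the limit of > 10000 nM in this assay, at which 2 of the 2 values shown sit. Compound 3 `CO[C@@H]1[C@H](N(C)c2ncc(-c3c[nH]c4ccc(Br)cc34)s2)C[C@H]2O[C@]1(C)n1c3ccccc3c3c4c(c5c6cc(Cl)ccc6n2c5c31)C(=O)NC4` differs from compound 2 by bromo in place of hydrogen on an aromatic carbon. Going by the values given here, with no measured step to lean on and both known values at the limit, no change beyond the scatter is expected in this assay. Compound 3 is estimated at 15000 nM, with a range from 4000 nM to 60000 nM, which means an expected step that the limit leaves unreadable from compound 2 to compound 3, and most likely another limit.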

Compound 3, half-maximal inhibitory concentration: > 10000 nM
Compound 3: a limit, no number; the forecaster's own chance of this, stated with the estimate: 70%; the middle value lies beyond the limit too.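

In this assay compound 3 gives only the limit > 10000 nM and compound 2 also gives only a limit, so no step between them can be read: the limit of > 10000 nM in this assay, at which 3 of the 3 values shown sit.
The compounds shown leave open whether bromo in place of hydrogen changes the activity at all, and what true number any of the three compounds would have.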